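This account rests on a few compounds, and the source may have more. Where it says the series, first, only, none or still open, it means among the compounds named here.

Measured in an ADME assay on T29 cells (Homo sapiens) for cytotoxicity, read by sulforhodamine B assay, with a stated time of 3 days; on this read-out lower numbers stand for stronger inhibition and higher numbers for weaker inhibition:
compound 1 `OCc1cn(Cc2cccc(Cl)c2)c2ccccc12`: > 31600 nM
compound 2 `OCc1cn(Cc2ccc(Cl)cc2)c2ccccc12`: > 31600 nM
compound 3 `O=[N+]([O-])c1cccc(Cn2cc(CO)c3ccccc32)c1`: > 31600 nM

Each of these entries is a limit of the assay and not a number.

Compound 2 stands at > 31600 nM, which is a limit. It shares that position with the other two compounds, as the limit of > 31600 nM in this assay, at which 3 of the 3 values shown sit, shows, so the three cannot be put in any order.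

Compound 4 `O=[N+]([O-])c1ccc(Cn2cc(CO)c3ccccc32)cc1` differs from compound 2 in one place: nitro in place of chloro on an aromatic carbon. This is nitro in place of chloro on an aromatic carbon, para to a large group.

Going by the values given here, one measured step bears on this change, since it is the same kind of swap: a step that the two limits leave unreadable from compound 1 to compound 3. That step has no readable size. Compound 3, which carries the nitro, still gives > 31600 nM, again a limit. With that single result as a guide, no step beyond the usual scatter is expected in this assay, and compound 4 will most likely end at the same limit. The step expected here is a number no higher from compound 2 to compound 4 (the limit leaves the size open), an estimate that the limit of compound 2 leaves loose. For compound 4 the estimate is 31600 nM, with an expected range from 15000 nM to 50000 nM.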

Compound 4, half-maximal inhibitory concentration: > 31600 nM
Compound 4 was reported as a limit (the forecaster's own chance of this, stated with the estimate: 80%); the middle value sits exactly at the limit.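

In this assay compound 4 gives > 31600 nM, which is a limit of the assay and not a number. No step can be read from compound 2 to compound 4, where nitro takes the place of chloro, since both entries are limits: the limit of > 31600 nM in this assay, at which 4 of the 4 values shown sit. The compounds shown leave open how the four would rank in this assay and whether this change alters the read-out at all.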